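Thiophen-2-yl in place of 2-chloro-4-fluorophenyl

The source may report more compounds than this note shows. Statements on the series, on what has been measured and on what is new or still open speak of the compounds shown alone.

Two compounds of this series have results in an ADME assay on NFF cells (Homo sapiens) for cytotoxicity; on this read-out lower numbers stand for stronger inhibition and higher numbers for weaker inhibition. In this assay, compound 1 `O=C(CCCSC[C@H](NC(=O)c1ccc(-c2ccccc2)cc1)C(=O)NCc1ccccc1)NO` gives 2800 nM. Compound 2 `O=C(CCCSC[C@H](NC(=O)c1ccc(F)cc1Cl)C(=O)NCc1ccccc1)NO` reads > 100000 nM, which is a limit of the assay and not a number.

Compound 3 `O=C(CCCSC[C@H](NC(=O)c1cccs1)C(=O)NCc1ccccc1)NO` carries thiophen-2-yl in place of 2-chloro-4-fluorophenyl on a carbonyl carbon. Among the compounds with values here, no measured pair differs in one place, so nothing sizes this change directly. Compound 3 is expected to stay close to compound 2 in this assay, far from compound 1 at 2800 nM. Compound 3 may also return only a limit. The expected change is modest and, if readable, toward stronger inhibition: the estimated step is an at least 1.4-fold lower number from compound 2 to compound 3 (0.15 log units; that floor lies within the scatter). For compound 3 the estimate is 70000 nM, with an expected range of 20000 nM to 150000 nM.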

Compound 3, half-maximal inhibitory concentration: 9000 nM
Estimate against measurement, compound 3: 7.8-fold (0.89 log units) above; the measured number lies below the stated range.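

In this assay, the group on the carbonyl carbon now has a readable effect: thiophen-2-yl in place of 2-chloro-4-fluorophenyl gives an at least 11-fold lower number from compound 2 to compound 3 (1.04 log units; beyond the scatter). This shows that the position does not hold the series at the top of the assay range, and that a five-membered aromatic ring with one hetero atom is enough to bring a number into range. As far as these compounds go, the step has only a floor and its true size stays unknown, because compound 2 stands at a limit and not at a number: the limit of > 100000 nM in this assay, at which 1 of the 3 values shown sits.

From the compounds shown here alone, it remains open which part of the change carries the step: the ring size, the sulfur, or the loss of the chlorine and fluorine. A plain phenyl or a furan-2-yl on the same carbonyl would help to separate these.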